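A few compounds are considered here, and "the series" means these few. Any claim that something is new, unique, unknown or untested is made for them only; others in the source may bear on it.

Among the compounds with values here, compound 2 `O=Cc1ccc(-c2cn3ccnc3c(-c3ccc4ncn(C5CCCCC5)c4c3)n2)cc1` stands at the top of the two numbers so far in a functional assay on OVCAR-4 cells (Homo sapiens) for inhibition, read by sulforhodamine B assay, with a stated time of 48 h, tested at 10 uM (on this read-out higher numbers stand for more inhibition at the one concentration tested (going by the name of the read-out) and lower numbers for less inhibition), giving 16.9%. Within the data shown here, its only neighbour is compound 1 `Brc1cn2ccnc2c(-c2ccc3ncn(C4CCCCC4)c3c2)n1`, which in this assay gives 9.15%; the step of a number 7.8 percentage points higher from compound 1 to compound 2 (within the scatter) is within the scatter, so the two cannot be ordered. Compound 3 `Brc1ccc(-c2cn3ccnc3c(-c3ccc4ncn(C5CCCCC5)c4c3)n2)cc1` is not yet measured. It differs from compound 2 by bromo in place of formyl on an aromatic carbon. Among the measured compounds shown here, the one measured step, 4-formylphenyl in place of bromo on an aromatic carbon, exchanged a whole group for a single atom and was itself small; it does not show what bromo in place of formyl on an aromatic carbon does to the read-out. No step beyond the scatter is therefore expected in this assay, in either direction, and compound 3 is expected to give about 13%, between 0% and 30%, which would be a step of a number 3.9 percentage points lower from compound 2 to compound 3 (within the scatter).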

Compound 3, a percentage reported as inhibition, at one concentration (the size of the read-out at that concentration, not a potency): 10.5%
The estimate for compound 3 lay 2.5 percentage points above the measured number, and the stated range covers the measured number.
By their numbers in this assay, from the lowest: compounds 1, 3 and 2 (each within the scatter of the next).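

On the six-membered aromatic ring of carbon only, at the carbon para to a large group, bromo and formyl are not told apart in this assay: the exchange gives a number 6.4 percentage points lower from compound 2 to compound 3 (within the scatter) and is no readable change. The 4-bromophenyl in place of the bromo on the shared core gives a number 1.4 percentage points higher from compound 1 to compound 3 (within the scatter) and so adds no readable change either, which means neither change tested so far separates these compounds. No available evidence bears on why these steps are small.

Still open, as far as these compounds go, is whether any group at this position can move the read-out beyond the scatter, for example an amine or a carboxylic acid in place of the bromo of compound 3. With all three numbers this close together, the contribution of the rest of the core also remains unresolved.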